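The source may report more compounds than this note shows. Statements on the series, on what has been measured and on what is new or still open speak of the compounds shown alone.

Measured in a functional assay on HL-60 cells (Homo sapiens) for cytotoxicity, read by CCK-8 assay, with a stated time of 24 h; on this read-out higher numbers stand for weaker inhibition and lower numbers for stronger inhibition:
Compound 1 `C=CC(=O)N1C(=O)CC(C)Sc2ccccc21`: 199000 nM
Compound 2 `C=CC(=O)N1C(=O)CC(c2ccccc2)Sc2ccccc21`: 97400 nM

Compound 2 has the lower of the two numbers, 97400 nM. Compound 3 `C=CC(=O)N1C(=O)CC(c2ccc(C#N)cc2)Sc2ccccc21` carries cyano in place of hydrogen on an aromatic carbon of the phenyl, para to a large group: cyano in place of hydrogen on an aromatic carbon. Among the compounds with values here, only one measured step bears on this, the modest 2.0-fold lower number from compound 1 to compound 2 (0.31 log units; beyond the scatter), which came from phenyl in place of methyl on a saturated ring carbon. It is a different change, so only a small move towards a lower number is expected in this assay, and it may stay within the scatter. The expected step is a 1.3-fold lower number from compound 2 to compound 3 (0.11 log units; within the scatter). For compound 3 the estimate is 75000 nM, with an expected range of 30000 nM to 170000 nM.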

Compound 3, half-maximal inhibitory concentration: 115000 nM
Estimate against measurement, compound 3: 1.5-fold (0.19 log units) below, and the stated range covers the measured number.
By their numbers in this assay, from the lowest: compounds 2, 3 and 1 (each within the scatter of the next, the first and the last beyond it).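

In this assay, cyano on an aromatic carbon of the phenyl, para to a large group, gives a 1.2-fold higher number from compound 2 to compound 3 (0.07 log units; within the scatter), so this change leaves the number within the scatter of compound 2. Set against the methyl of compound 1, the 4-cyanophenyl gives a 1.7-fold lower number from compound 1 to compound 3 (0.24 log units; within the scatter), which also lies within the scatter, whereas the plain phenyl of compound 2 stood beyond it. No measurement at hand accounts for either result. The compounds shown leave open whether an amine, a carboxylic acid or a methoxy group at this same place would move the number beyond the scatter.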